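The source may hold more compounds than are shown below. What is called first, only, known or untested is meant among the compounds shown, and "the series" means these compounds.

Measured so far:

compound 1 `Cc1ccc(C(=O)NNC(=O)c2cccc(NS(=O)(=O)c3cnc(O)nc3O)c2)cc1` — > 20000 nM
compound 2 `O=C(NNC(=O)c1ccccc1Cl)c1cccc(NS(=O)(=O)c2cnc(O)nc2O)c1` — 3740 nM
compound 3 `Cc1ccc(C(=O)NNC(=O)c2ccccc2NS(=O)(=O)c2cnc(O)nc2O)cc1` — > 20000 nM

Of the compounds shown here, three have been tested in a functional assay on A549 cells (Homo sapiens) for antiproliferative activity, read by MTT assay, with a stated time of 24 h; on this read-out lower numbers stand for stronger inhibition and higher numbers for weaker inhibition. Compound 1 gives > 20000 nM, which is a limit of the assay and not a number. Compound 3 likewise gives > 20000 nM, again a limit. For the measured compounds named here, compound 2 is the one compound with a measured number, 3740 nM, so that the pair of compounds 1 and 2 gives an at least 5.3-fold lower number from compound 1 to compound 2 (0.72 log units; beyond the scatter); the change behind this step is 2-chlorophenyl in place of 4-methylphenyl on a carbonyl carbon. Because (the limit of > 20000 nM in this assay, at which 2 of the 3 values shown sit), the true size of that step is open at its upper end.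

Compounds 1 and 3 have the same atoms joined differently; the difference between the two cores is not broken down here.

Compound 4 `O=C(NNC(=O)c1ccccc1NS(=O)(=O)c1cnc(O)nc1O)c1ccccc1Cl` is not yet measured. Its relation to compound 3 is 2-chlorophenyl in place of 4-methylphenyl on a carbonyl carbon, the same change as that from compound 1 to compound 2. The expectation for compound 4 rests on this one pairing: compound 3 sits at the limit, and the same change carried compound 1 to a measured number in compound 2, as seen in an at least 5.3-fold lower number from compound 1 to compound 2 (0.72 log units; beyond the scatter). A step of similar direction, an at least 2.8-fold lower number from compound 3 to compound 4 (0.45 log units; beyond the scatter), is therefore expected for compound 4, with the caution that the change has been seen only once and on a different core. Compound 4 is expected to give about 7000 nM, within a range from 1500 nM to 25000 nM.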

Compound 4, half-maximal inhibitory concentration: 5290 nM
Estimate against measurement, compound 4: 1.3-fold (0.12 log units) above; measured number inside the range.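

In this assay, 2-chlorophenyl in place of 4-methylphenyl on a carbonyl carbon gives an at least 3.7-fold lower number from compound 3 to compound 4 (0.57 log units; beyond the scatter), so the change that brought a measured number on the core of compound 1 does the same on the core of compound 3. The two steps run in the same direction on two cores, which shows that the direction carries over in this small set, but it does not show that the size carries over: the same change on two cores in this assay, an at least 5.3-fold lower number (0.72 log units; beyond the scatter) from compound 1 to compound 2 and an at least 3.7-fold lower number (0.57 log units; beyond the scatter) from compound 3 to compound 4; the limit leaves it open whether they differ. For the compounds shown here, this is a single change seen on only two cores, so it gives no rule for other groups or other cores, and the upper end of each step stays unknown: the limit of > 20000 nM in this assay, at which 2 of the 4 values shown sit.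

The compounds shown leave open whether the lower numbers depend on the chlorine or on the loss of the methyl group, since neither a plain phenyl ring nor a phenyl ring carrying another group appears on that carbonyl carbon. They also leave open how a quite different group in the same place, such as an amine, a carboxylic acid or a longer chain, would fare on either core.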